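Working notes: chloro to methyl, compound 3 to compound 4

A few compounds are considered here, and "the series" means these few. Any claim that something is new, unique, unknown or untested is made for them only; others in the source may bear on it.

Measured compounds:
compound 1, `NC(=O)c1ccccc1NC(=O)c1cn(-c2ccccc2)nc1-c1ccc(Cl)cc1`: 3.45%
compound 2, `NC(=O)c1ccccc1OC(=O)c1cn(-c2ccccc2)nc1-c1ccc(Br)cc1`: 8.6%
compound 3, `CC(=O)Nc1ccc(OC(=O)c2cn(-c3ccccc3)nc2-c2ccc(Cl)cc2)cc1`: 16.7%

In a functional assay on the whole organism (strain albino) for inhibition, with Rattus norvegicus as the target, read by paw edema, with stated times of 30 min and 3 h, at a dose of 50 mg/kg by the oral route (a higher number here means more inhibition at the dose given (going by the name of the read-out), a lower number less inhibition), compound 3 gives 16.7%, the highest of the three numbers. The gap to compound 2, which gives 8.6%, is within the scatter, so the two are not ordered. The gap to compound 1, which gives 3.45%, is beyond the scatter. Among the measured compounds no pair differs in one place only, so no measured step is available to guide the next one.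

Compound 4, `CC(=O)Nc1ccc(OC(=O)c2cn(-c3ccccc3)nc2-c2ccc(C)cc2)cc1`, differs from compound 3 in one place: methyl in place of chloro on an aromatic carbon. Among the compounds with values here, with no comparable step among the measured compounds, the expectation rests on compound 3 alone, and a step of a number 1.7 percentage points lower from compound 3 to compound 4 (within the scatter) that stays within the scatter is expected, in no clear direction. Compound 4 is therefore expected to give about 15%, with a range from 4% to 28%.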

Compound 4, a percentage reported as inhibition, in the whole organism at one dose (the size of the read-out at that dose, not a potency): 6.32%
The estimate for compound 4 lay 8.7 percentage points above the measured number; low and high end bracket the measured number.
By their numbers in this assay, from the lowest: compounds 1, 4, 2 and 3 (each within the scatter of the next, the first and the last beyond it).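

In this assay, the series now has its first comparison of compounds that differ in one place: a number 10.4 percentage points lower from compound 3 to compound 4 (beyond the scatter). At this position, on an aromatic carbon para to a large group, 4-chlorophenyl and 4-methylphenyl are therefore not interchangeable, at least on the core of compound 3, and chloro gives the higher number of this pair. No measured information at hand accounts for the step.

This single pair gives no trend across substituents, and it cannot be said whether the same change would behave alike on the core of compound 1 or compound 2. Still open, from the compounds shown here alone, is how fluoro, methoxy, an amine or a carboxylic acid at this position would read against chloro and methyl.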